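Swapping an aryl group on a shared pyridazinone core

The compounds below may be only part of what the source reports. "The series", "measured", "known", "first", "only" and "open" are said of these compounds alone.

Measured so far:
compound 1, `Cc1cc(=O)n(-c2cccc(F)c2)nc1C(=O)Nc1ccc(Oc2ncnc3[nH]ccc23)c(F)c1`: 32000 nM
compound 2, `Cc1ccc(-n2nc(C(=O)Nc3ccc(Oc4ncnc5[nH]ccc45)c(F)c3)c(C)cc2=O)cc1`: 18900 nM
compound 3, `Cc1cc(=O)n(-c2cccc(F)c2)nc1C(=O)Nc1ccc(Oc2ncnc3c2ccn3C)c(F)c1`: > 60000 nM

All three were tested in a functional assay on MCF7 cells (Homo sapiens) for cytotoxicity, read by MTT assay, with a stated time of 72 h; on this read-out lower numbers stand for stronger inhibition and higher numbers for weaker inhibition. Compound 1 gives 32000 nM there. Compound 2 carries 4-methylphenyl in place of 3-fluorophenyl on an aromatic nitrogen and gives 18900 nM, which is a 1.7-fold lower number from compound 1 to compound 2 (0.23 log units; within the scatter). Compound 3 differs from compound 1 by methyl in place of hydrogen on an aromatic nitrogen. For compound 3 this assay reports only a limit, > 60000 nM, not a number. That point is the limit of > 60000 nM in this assay, at which 1 of the 3 values shown sits. The step of an at least 1.8-fold higher number from compound 1 to compound 3 (0.27 log units; that floor lies within the scatter) is therefore known only as a floor.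

Compound 4, `Cc1ccc(-n2nc(C(=O)Nc3ccc(Oc4ncnc5c4ccn5C)c(F)c3)c(C)cc2=O)cc1`, has not yet been measured in this assay. It differs from compound 3 by 4-methylphenyl in place of 3-fluorophenyl on an aromatic nitrogen, the same change already made between compound 1 and compound 2, and placed in exactly the same surroundings. The two cores differ by methyl in place of hydrogen on an aromatic nitrogen.

The earlier instance of this change, a 1.7-fold lower number from compound 1 to compound 2 (0.23 log units; within the scatter), moved the number little. Compound 4 is therefore expected to sit close to compound 3, and since compound 3 rests on a limit, compound 4 may itself come back as a limit. Compound 4 is estimated at 60000 nM in this assay, between 30000 nM and 130000 nM. The expected step is a number no higher from compound 3 to compound 4 (the limit leaves the size open).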

Compound 4, half-maximal inhibitory concentration: > 60000 nM
Compound 4 was reported as a limit; the forecaster's own chance of this, stated with the estimate: 55%; the middle value lies on the limit itself.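

Putting 4-methylphenyl in place of 3-fluorophenyl on the core of compound 3 gives a step that cannot be read, because compound 3 and compound 4 both rest on the same limit rather than on numbers: the limit of > 60000 nM in this assay, at which 2 of the 4 values shown sit.

The methyl on the aromatic nitrogen can be followed a little further, since this assay gives an at least 3.1-fold higher number from compound 2 to compound 4 (0.50 log units; beyond the scatter). This shows that adding that methyl to the core of compound 2 raises the number clearly, but the same change on the core of compound 1 has a floor within the scatter, and neither step has a known size, so the data cannot say whether the change carries over from one core to the other with the same effect: the same change on two cores in this assay, an at least 1.8-fold higher number (0.27 log units; that floor lies within the scatter) from compound 1 to compound 3 and an at least 3.1-fold higher number (0.50 log units; beyond the scatter) from compound 2 to compound 4; the limit leaves it open whether they differ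

The compounds shown leave open how far the number would move with other groups on the same aromatic nitrogen in place of methyl, such as an ethyl group or a longer chain ending in an amine. They also leave open whether an aryl group carrying a carboxylic acid or an amine, in place of 3-fluorophenyl or 4-methylphenyl, would bring the methylated core back to a readable number.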